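Exchanging the aryl group on the shared core's ring nitrogen

A few compounds are considered here, and "the series" means these few. Any claim that something is new, unique, unknown or untested is made for them only; others in the source may bear on it.

Measured compounds:
compound 1, `C=CC(=O)Nc1cccc(NC(=O)CSc2nc(Nc3cccc([N+](=O)[O-])c3)c3ccccc3n2)c1` — > 50000 nM
compound 2, `C=CC(=O)Nc1cccc(NC(=O)CSc2nc(Nc3cc(OC)c(OC)c(OC)c3)c3ccccc3n2)c1` — > 50000 nM

In a functional assay on MGC-803 cells (Homo sapiens) for inhibition, read by MTT assay, with a stated time of 72 h (on this read-out lower numbers stand for stronger inhibition and higher numbers for weaker inhibition), compound 1 gives only a limit of the assay, > 50000 nM. In this assay compound 2 likewise gives only a limit of the assay, > 50000 nM. The step that the two limits leave unreadable from compound 1 to compound 2 cannot be read in size or direction, because both values sit at the limit of > 50000 nM in this assay, at which 2 of the 2 values shown sit. Compound 2 thus stands at the limit of the numbers shown, and nothing in those numbers separates it from compound 1.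

Compound 3, `C=CC(=O)Nc1cccc(NC(=O)CSc2nc(Nc3ccc(Cl)cc3Cl)c3ccccc3n2)c1`, has not yet been measured in this assay. It differs from compound 2 by 2,4-dichlorophenyl in place of 3,4,5-trimethoxyphenyl on a nitrogen on an aromatic ring. Within the data shown here, the only measured step that bears on a change at this position is the one from compound 1 to compound 2, and it is unreadable, so no readable guide to the size or direction of the new step exists. Compound 3 is therefore expected to give only a limit again, with an estimated step that the limit leaves unreadable from compound 2 to compound 3. For compound 3 the estimate in this assay is 70000 nM, with a range from 20000 nM to 250000 nM.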

Compound 3, half-maximal inhibitory concentration: 12100 nM
Compound 3: middle estimate off by 5.8-fold (0.76 log units), on the high side, outside the stated range (below it).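

In this assay, placing 2,4-dichlorophenyl on a nitrogen on an aromatic ring gives an at least 4.1-fold lower number from compound 2 to compound 3 (0.61 log units; beyond the scatter) when it replaces 3,4,5-trimethoxyphenyl, and an at least 4.1-fold lower number from compound 1 to compound 3 (0.61 log units; beyond the scatter) when it replaces 3-nitrophenyl. These steps show that the aryl group at this place can shift the number in this cell assay, something the earlier pair could not show, because its step cannot be read: the limit of > 50000 nM in this assay, at which 2 of the 3 values shown sit. As far as these compounds go, compound 3 is the only one of the three with a measured number, 12100 nM, so each step gives only a minimum size and the true gaps remain unknown.

The compounds shown do not reveal what it is about 2,4-dichlorophenyl that goes with the lower number, and a single comparison group with a number cannot establish a trend across aryl groups. From the compounds shown here alone, it remains open how a phenyl group carrying only one chlorine would compare, or one with bromine atoms or methyl groups in place of the two chlorines, and whether changes elsewhere on the shared core would shift the number further.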